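Series notes: benzimidazolyl to trifluoromethyl-triazolyl on the acetamide arm

The compounds below may be only part of what the source reports. "The series", "measured", "known", "first", "only" and "open" are said of these compounds alone.

Three compounds have numbers in an assay on blood for inhibition of C-X-C chemokine receptor type 3 (Homo sapiens), with a stated time of 30 min; a lower number here means a stronger inhibitor, a higher number a weaker inhibitor. Compound 1 `Cc1nc(-c2nc3ccccc3[nH]2)c(N2CCN(C(=O)Cn3cnc4cccnc43)[C@H](C)C2)s1` gives 1060 nM in this assay. Within the data shown here, compound 2 `C[C@@H]1CN(c2sc(CO)nc2-c2nc3ccccc3[nH]2)CCN1C(=O)Cn1cnc2cccnc21` gives 3380 nM in this assay, and the step of a 3.2-fold higher number from compound 1 to compound 2 (0.50 log units; beyond the scatter) is the only single-point change measured so far. Among the measured compounds shown here, compound 3 `CCOc1ncc(-c2nc(C(F)(F)F)sc2N2CCN(C(=O)Cn3cnc4ccccc43)[C@H](C)C2)cn1` gives 192 nM in this assay, the lowest of the three numbers; compound 1 lies nearest and compound 2 furthest, both beyond the scatter, and compound 3 differs from each of them in more than one place, so no single step can be drawn from those pairs.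

Compound 4 `CCOc1ncc(-c2nc(C(F)(F)F)sc2N2CCN(C(=O)Cn3cnc(C(F)(F)F)n3)[C@H](C)C2)cn1` is not yet measured. It differs from compound 3 in one place: 3-(trifluoromethyl)-1H-1,2,4-triazol-1-yl in place of 1H-benzimidazol-1-yl on a saturated chain carbon bound to a carbonyl carbon. The measured step concerns a hydroxy on the other side of the shared core and does not bear on this change; nothing in the data speaks to exchanging 1H-benzimidazol-1-yl for 3-(trifluoromethyl)-1H-1,2,4-triazol-1-yl on a saturated chain carbon bound to a carbonyl carbon. For the measured compounds named here, with no guiding step, the expectation for compound 4 is a modest rise in this assay, a 2.3-fold higher number from compound 3 to compound 4 (0.37 log units; beyond the scatter), carrying a wide range. Compound 4 is estimated at 450 nM in this assay, between 130 nM and 1600 nM.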

Compound 4, half-maximal inhibitory concentration: 524 nM
The estimate for compound 4 lay 1.2-fold (0.07 log units) below the measured number; the range from low to high includes it.
By their numbers in this assay, from the lowest: compound 3; then compound 4; then compound 1; then compound 2.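

The saturated chain carbon bound to a carbonyl carbon now has a single-point change of its own: in this assay, 3-(trifluoromethyl)-1H-1,2,4-triazol-1-yl in place of 1H-benzimidazol-1-yl gives a 2.7-fold higher number from compound 3 to compound 4 (0.44 log units; beyond the scatter). The position therefore registers this exchange, with a step beyond the scatter but only modest in size, even though the entering group has no six-membered aromatic ring of carbon only and matches the leaving group in heavy-atom count. No measurement on these compounds accounts for the rise in the number.

On these data alone, the exchange removes the six-membered ring, adds a ring nitrogen and brings in a trifluoromethyl group all at once, and the share of each in the step stays open. As far as these compounds go, an unsubstituted 1H-1,2,4-triazol-1-yl group or a triazole carrying a methyl group in place of trifluoromethyl would begin to separate these parts, and it also remains open whether the step would carry over to the core of compound 1.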